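The source may report more compounds than this note shows. Statements on the series, on what has been measured and on what is new or still open speak of the compounds shown alone.

In a functional assay on HeLa cells (Homo sapiens) for antiproliferative activity, read by MTT assay, with a stated time of 72 h (a lower number here means a stronger inhibitor, a higher number a weaker inhibitor), compound 1 `CNC(=O)c1cc(Oc2ccc(NC(=O)c3nn(-c4ccccc4Cl)c(=O)cc3C)cc2F)ccn1` gives 9870 nM and compound 2 `CCCNC(=O)c1cc(Oc2ccc(NC(=O)c3nn(-c4cccc(C(F)(F)F)c4)c(=O)cc3C)cc2F)ccn1` gives 8000 nM as its half-maximal inhibitory concentration. These two numbers lie within the usual scatter of each other, so compound 2 stands level with compound 1 and the pair cannot be ranked. Compound 3 `CNC(=O)c1cc(Oc2ccc(NC(=O)c3nn(-c4cccc(C(F)(F)F)c4)c(=O)cc3C)cc2F)ccn1` has not yet been measured. It differs from compound 2 in one place, on a saturated chain carbon bound to an amide-type nitrogen, and hydrogen in place of ethyl on a saturated chain carbon bound to an amide-type nitrogen is the whole of that difference: hydrogen in place of ethyl, which turns propylcarbamoyl to methylcarbamoyl. Among the measured compounds shown here, no measured pair isolates this change, so its size in this assay cannot be read directly. The expectation is no step beyond the scatter, in either direction. Compound 1 already carries methylcarbamoyl, with a different group on the shared core, and gives 9870 nM without separating from compound 2. The estimated change is a 1.1-fold higher number from compound 2 to compound 3 (0.03 log units; within the scatter) and it is expected to stay small. For compound 3 the estimated value is 8500 nM with an expected range from 3500 nM to 20000 nM across repeat measurements.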

Compound 3, half-maximal inhibitory concentration: 11800 nM
Beside the measured number, compound 3's estimate is 1.4-fold (0.14 log units) below it; measured number inside the range.
By their numbers in this assay, from the lowest: compounds 2, 1 and 3 (each within the scatter of the next).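

In this assay, the change at this position can now be read on its own: hydrogen in place of ethyl on a saturated chain carbon bound to an amide-type nitrogen, which turns propylcarbamoyl to methylcarbamoyl, gives a 1.5-fold higher number from compound 2 to compound 3 (0.17 log units; within the scatter) and so does not separate the two compounds. Among the compounds shown here, the group on the aromatic nitrogen can also be read on its own for the first time, as 3-(trifluoromethyl)phenyl in place of 2-chlorophenyl with methylcarbamoyl held constant gives a 1.2-fold higher number from compound 1 to compound 3 (0.08 log units; within the scatter), so this change does not separate its pair either. Thus neither of the two single changes shown moves the number beyond the scatter, and nothing at hand offers an explanation for these results.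

The compounds shown leave open whether a longer chain such as hexyl, or a chain ending in an amine or a carboxylic acid, would give a step beyond the scatter at this position. Going by these compounds, whether a methoxy group or a nitrile on the phenyl group carried by the aromatic nitrogen would do so remains equally open.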